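Swapping a Phenyl for a Tosyl Group on Compound 3

A few compounds are considered here, and "the series" means these few. Any claim that something is new, unique, unknown or untested is made for them only; others in the source may bear on it.

Of the compounds shown here, three have been measured in a functional assay on MGC-803 cells (Homo sapiens) for inhibition, read by MTT assay, with a stated time of 48 h, tested at 20 uM; on this read-out higher numbers stand for more inhibition at the one concentration tested (going by the name of the read-out) and lower numbers for less inhibition. Compound 1, `CCCn1c(SCC(=O)Nc2ccc(C)cc2)nc2c1c(=O)[nH]c(=O)n2C`, gives 42.2%. Compound 2, `Cn1cnc2c1c(=O)n(CC(=O)N1CCSCC1)c(=O)n2C`, gives 5.6%. Compound 3, `Cn1cnc2c1c(=O)n(CC(=O)N1CCN(c3ccccc3)CC1)c(=O)n2C`, gives 4.6%. On these numbers compound 3 has the smallest value of the three, but its gap to compound 2 lies within the usual scatter, so the two cannot be told apart; only compound 1 stands clearly apart, and it sits beyond the scatter from compound 3.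

Compound 4, `Cc1ccc(S(=O)(=O)N2CCN(C(=O)Cn3c(=O)c4c(ncn4C)n(C)c3=O)CC2)cc1`, has not yet been measured. Compared with compound 3, the change is (4-methylphenyl)sulfonyl in place of phenyl on an amine nitrogen in a ring. The shared core and the amide linker stay untouched; only the group on the ring nitrogen is exchanged.

Among the compounds with values here, with no measured pair showing this change, the expectation rests on compound 3 alone. Because compound 3 gives only 4.6%, and compound 2, with a different group on a similar ring, also sits low, the step expected in this assay is a number 3.4 percentage points higher from compound 3 to compound 4 (within the scatter), a change of no clear size beyond the scatter. Compound 4 is therefore estimated to give 8%, with a range from 0% to 25%.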

Compound 4, a percentage reported as inhibition, at one concentration (the size of the read-out at that concentration, not a potency): 20.1%
The estimate for compound 4 lay 12.1 percentage points below the measured number; low and high end bracket the measured number.
By their numbers in this assay, from the lowest: compounds 3 and 2 (each within the scatter of the next); then compound 4; then compound 1.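

In this assay, within the data shown here, putting (4-methylphenyl)sulfonyl in place of phenyl on the amine nitrogen of the six-membered ring gives a number 15.5 percentage points higher from compound 3 to compound 4 (beyond the scatter), the first step in this set that can be read between two compounds differing in one place. The shared core and the amide linker stay the same, so this nitrogen is a position where exchanging the group alone moves the read-out by more than repeated measurements would, although the step is modest and comes from a single pair. Nothing measured here explains why the number rises with this exchange.

This one step cannot show whether the sulfonyl link or the methyl on the aromatic ring accounts for the rise; a plain phenylsulfonyl group, without the methyl, or a methanesulfonyl group, without the aromatic ring, on the same nitrogen would help to separate the two. Since every number comes from one tested concentration, the compounds shown also leave open how potency changes across this exchange.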